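Chloro in place of fluoro on the shared core

The source may report more compounds than this note shows. Statements on the series, on what has been measured and on what is new or still open speak of the compounds shown alone.

Compound 1 `O=C(NO)c1ccc(CN2C(=O)/C(=C3\Nc4ccccc4\C3=N/O)c3cc(F)ccc32)cc1` gives 50 nM in a functional assay on PC-3 cells (Homo sapiens) for cytotoxicity, read by colorimetric assay (on this read-out higher numbers stand for weaker inhibition and lower numbers for stronger inhibition), level with compound 2 `O=C(/C=C/c1ccc(CN2C(=O)/C(=C3\Nc4ccccc4\C3=N/O)c3cc(F)ccc32)cc1)NO` at 50 nM and together the lowest of the three numbers; the step of no change at the digits printed from compound 1 to compound 2 (within the scatter) stays within the scatter. Compound 3 `O=C(/C=C/c1ccc(CN2C(=O)/C(=C3\Nc4ccccc4\C3=N/O)c3cccc(Cl)c32)cc1)NO` gives 90 nM, also within the scatter of compound 1. Compound 4 `O=C(NO)c1ccc(CN2C(=O)/C(=C3\Nc4ccccc4\C3=N/O)c3cc(Cl)ccc32)cc1` differs from compound 1 by chloro in place of fluoro on an aromatic carbon. Within the data shown here, no measured step isolates this halogen swap: compound 3 differs from compound 2 in both halogen and place, and their values differ within the scatter. Compound 4 is therefore expected to give 60 nM, between 25 nM and 150 nM. The step of a 1.2-fold higher number from compound 1 to compound 4 (0.08 log units; within the scatter) is expected to stay within the scatter.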

Compound 4, half-maximal inhibitory concentration: 50 nM
Estimate against measurement, compound 4: 1.2-fold (0.08 log units) above; measured number inside the range.
By their numbers in this assay, from the lowest: compounds 1, 2, 4 and 3 (each within the scatter of the next).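

In this assay, among these compounds, chloro in place of fluoro on this aromatic carbon gives no change at the digits printed from compound 1 to compound 4 (within the scatter) and so isolates the halogen swap, which no earlier step did. With hydroxycarbamoyl on the shared core, this carbon thus carries either halogen with the step staying within the scatter. Nothing measured here accounts for this result.

Going by these compounds, whether an amine or a methoxy group on this carbon would also stay within the scatter remains open. So does the effect of chloro at this place when 2-(hydroxycarbamoyl)ethenyl stands in place of hydroxycarbamoyl.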